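The compounds below may be only part of what the source reports. "The series", "measured", "known", "first", "only" and "open" are said of these compounds alone.

Working notes on the series.

The shared core carries an anilide on the aniline ring, and the two measured compounds differ only in the group on the benzoyl ring. Compound 1 `COc1cc2ncnc(Nc3ccc(NC(=O)c4ccc(C)cc4)cc3)c2cc1OC` in a functional assay on MCF7 cells (Homo sapiens) for inhibition, read by MTT assay (a lower number here means a stronger inhibitor, a higher number a weaker inhibitor), gives 19000 nM. Compound 2 `COc1cc2ncnc(Nc3ccc(NC(=O)c4ccc(F)cc4)cc3)c2cc1OC` in this assay gives 27000 nM; this is the higher of the two numbers, with compound 1 the nearest and the only other point, and the step of a 1.4-fold higher number from compound 1 to compound 2 (0.15 log units; within the scatter) falls within the scatter, so the two compounds are not distinguished by these data.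

Compound 3 `COc1cc2ncnc(Nc3ccc(NC(=O)c4ccc(I)cc4)cc3)c2cc1OC` is not yet measured. Its difference from compound 2 is iodo in place of fluoro on an aromatic carbon. Among the compounds with values here, the only measured step that bears on this position is the one from compound 1 to compound 2, a 1.4-fold higher number from compound 1 to compound 2 (0.15 log units; within the scatter), which did not move the number beyond the scatter; no halogen larger than fluoro has been measured here, so no direction can be read from the series. The expectation for this assay is therefore a step of a 1.2-fold lower number from compound 2 to compound 3 (0.09 log units; within the scatter), that is, none beyond the scatter. Compound 3 is expected to give about 22000 nM, with a range from 8000 nM to 60000 nM.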

Compound 3, half-maximal inhibitory concentration: 48000 nM
Estimate against measurement, compound 3: 2.2-fold (0.34 log units) below; measured number inside the range.
By their numbers in this assay, from the lowest: compounds 1, 2 and 3 (each within the scatter of the next, the first and the last beyond it).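

In this assay this position now gives its first step beyond the scatter: iodo in place of methyl is a modest change, a 2.5-fold higher number from compound 1 to compound 3 (0.40 log units; beyond the scatter), and compound 3 is the weaker inhibitor of that pair. Iodo in place of fluoro, a 1.8-fold higher number from compound 2 to compound 3 (0.25 log units; within the scatter), stays within the scatter, so compound 2 and compound 3 are not told apart, just as compound 1 and compound 2 were not; the series therefore separates only at its two ends, and the position tolerates all three groups without a large step in either direction. Nothing at hand gives a reason for the separation between compound 1 and compound 3.

The compounds shown leave open how chloro or bromo at this position would read against fluoro and iodo, and whether the separation between methyl and iodo would hold up in a longer halogen and alkyl set. They also leave open whether an amine, a carboxylic acid or a methoxy group here would produce a step larger than the modest one seen so far.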